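A few compounds are considered here, and "the series" means these few. Any claim that something is new, unique, unknown or untested is made for them only; others in the source may bear on it.

Measured in an assay on isolated protein for inhibition of DNA topoisomerase 1 (Homo sapiens), with a stated time of 30 min, tested at 100 uM; a higher number here means a stronger effect of the compound at the concentration tested, a lower number a weaker effect:
compound 1 `Oc1ccc(-c2cc(-c3cccs3)cc(-c3ccccc3O)n2)cc1` gives 72.2%
compound 2 `Oc1ccc(-c2cc(-c3cccs3)cc(-c3cccc(O)c3)n2)cc1` gives 85.7%
compound 3 `Oc1cccc(-c2cc(-c3ccsc3)cc(-c3ccccc3O)n2)c1` gives 10.2%

For the measured compounds named here, the one measured instance of the change 3-hydroxyphenyl in place of 2-hydroxyphenyl on an aromatic carbon gave the step of a number 13.5 percentage points higher from compound 1 to compound 2 (beyond the scatter). Compound 3 sits on a different core; the difference between the core of compound 1 and the core of compound 3 is not broken down here, and compound 3 gives the lowest number of the three.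

Compound 4 `Oc1cccc(-c2cc(-c3ccsc3)cc(-c3cccc(O)c3)n2)c1` is not yet measured and differs from compound 3 by 3-hydroxyphenyl in place of 2-hydroxyphenyl on an aromatic carbon. This is the same kind of change, not the same: the place in compound 1 is meta to a 4-hydroxyphenyl group and meta to a thiophen-2-yl group, whereas in compound 3 it is meta to a 3-hydroxyphenyl group and meta to a thiophen-3-yl group. Going by the values given here, a step of about a number 14.8 percentage points higher from compound 3 to compound 4 (beyond the scatter) in this assay is expected, resting on the single earlier step of a number 13.5 percentage points higher from compound 1 to compound 2 (beyond the scatter) and on the low starting value of compound 3, 10.2%, with a wide band because only one instance of the change is known. Compound 4 is thus estimated at 25%, expected between 5% and 55%.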

Compound 4, a percentage reported as inhibition, at one concentration (the size of the read-out at that concentration, not a potency): 59.2%
For compound 4 the middle estimate is 34.2 percentage points below the measured one, outside the stated range (above it).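

In this assay, 3-hydroxyphenyl in place of 2-hydroxyphenyl on the second core gives a number 49 percentage points higher from compound 3 to compound 4 (beyond the scatter), so the direction of the change is the same on both cores shown. The size of the step does not carry over from one core to the other: the same change on two cores in this assay, a number 13.5 percentage points higher (beyond the scatter) from compound 1 to compound 2 and a number 49 percentage points higher (beyond the scatter) from compound 3 to compound 4, 35.5 percentage points apart, beyond the scatter of two such steps. Two pairs do not show which difference between the cores goes with the larger step, and they give no rule for the size of the step on a further core.

The compounds shown leave open whether the hydroxyl on this ring can give way to an amine or a carboxylic acid. They also leave open how the change behaves on a core without a thiophene.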